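The source may report more compounds than this note shows. Statements on the series, on what has been measured and on what is new or still open speak of the compounds shown alone.

Measured compounds in a functional assay on HeLa cells (Homo sapiens) for cytotoxicity, read by MTT assay; a higher number here means a weaker inhibitor, a lower number a stronger inhibitor: compound 1 `O=C1CC([C@H]2O[C@@H](n3ccc(=O)[nH]c3=O)[C@H](O)[C@@H]2O)SS1` with 62200 nM, and compound 2 `O=C1CC([C@H]2O[C@@H](n3ccc(=O)[nH]c3=O)[C@H](O)[C@@H]2O)[S+]([O-])S1` with 50700 nM. Compound 3 `Cc1cn([C@H]2C[C@H](O[Si](C)(C)C(C)(C)C)[C@@H](C3CC(=O)SS3)O2)c(=O)[nH]c1=O` has no number in this assay; for compound 3 the entry reads "not determined" (no result reported).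

Compound 1 and compound 2 differ in one place: a group of 7 heavy atoms (3 carbon, 2 oxygen, 2 sulfur; one five-membered non-aromatic ring with 2 hetero atoms) in place of a group of 6 heavy atoms (3 carbon, 1 oxygen, 2 sulfur; one five-membered non-aromatic ring with 2 hetero atoms), on a saturated ring carbon. That change gave a 1.2-fold lower number from compound 1 to compound 2 (0.09 log units; within the scatter), a step within the scatter. Compound 4 `Cc1cn([C@H]2C[C@H](O[Si](C)(C)C(C)(C)C)[C@@H](C3CC(=O)S[S+]3[O-])O2)c(=O)[nH]c1=O` carries the same kind of change on the core of compound 3: a group of 7 heavy atoms (3 carbon, 2 oxygen, 2 sulfur; one five-membered non-aromatic ring with 2 hetero atoms) in place of a group of 6 heavy atoms (3 carbon, 1 oxygen, 2 sulfur; one five-membered non-aromatic ring with 2 hetero atoms), on a saturated ring carbon. The place is not identical: in compound 1 the site is next to the ring atom that bears a hydroxy group, whereas in compound 3 the neighbouring ring atoms carry other groups, as the two descriptions of the change set out. The difference between the two cores is not broken down here. Since compound 3 has no value, the expectation for compound 4 rests only on compound 1 giving 62200 nM and compound 2 giving 50700 nM in this assay, with the change itself expected to move little, as a 1.2-fold lower number from compound 1 to compound 2 (0.09 log units; within the scatter) shows. Compound 4 is estimated at 45000 nM, with a wide range from 8000 nM to 250000 nM, because a 1.2-fold lower number from compound 1 to compound 2 (0.09 log units; within the scatter) lies within the scatter and the core of compound 3 is unmeasured.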

Compound 4, half-maximal inhibitory concentration: 43100 nM
The estimate for compound 4 lay 1.0-fold (0.02 log units) above the measured number, within the range that was stated.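

Going by these compounds alone, compound 4 yields no new step in this assay: compound 3 offers no single number to compare it with. The compounds shown leave open how this change acts on the core of compound 3. No evidence on hand bears on this result.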